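The source may hold more compounds than are shown below. What is called first, only, known or untested is meant among the compounds shown, and "the series" means these compounds.

Two compounds with a shared core and a three-carbon amine chain have been tested in an ADME assay on HepG2 cells (Homo sapiens) for cytotoxicity, read by luminescence, CellTiter-Glo and ATP content, with a stated time of 72 h; on this read-out higher numbers stand for an effect only at larger amounts of compound and lower numbers for an effect already at smaller amounts. Compound 1 `COc1ccc(F)cc1CNCCCNc1ccnc2cc(-c3ccccc3)ccc12` gives 2960 nM, while compound 2 `COc1ccccc1Oc1ccc2c(NCCCNCc3cccc(OC)c3O)ccnc2c1` gives 11200 nM. Compound 2 thus stands at the higher of the two numbers, and its gap to compound 1 lies beyond the usual scatter, so compound 2 acts only at larger amounts. Compound 3 `COc1ccc(F)cc1CNCCCNc1ccnc2cc(Oc3ccccc3OC)ccc12` keeps the 2-methoxyphenoxy group of compound 2 on the core and changes the benzyl part: 5-fluoro-2-methoxyphenyl in place of 2-hydroxy-3-methoxyphenyl on a saturated chain carbon bound to an amine nitrogen. This brings in the benzyl group already present in compound 1, where the number was lower than in compound 2. A modest move toward lower numbers is therefore expected, roughly the step of a 1.9-fold lower number from compound 2 to compound 3 (0.27 log units; within the scatter), which stays within or close to the scatter. The estimate for compound 3 in this assay is 6000 nM, with a likely range from 2500 nM to 14000 nM.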

Compound 3, half-maximal effective concentration: 6400 nM
For compound 3 the middle estimate is 1.1-fold (0.03 log units) below the measured one; the measured number falls inside the stated range.
By their numbers in this assay, from the lowest: compound 1; then compounds 3 and 2 (each within the scatter of the next).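

In this assay, 5-fluoro-2-methoxyphenyl in place of 2-hydroxy-3-methoxyphenyl on a saturated chain carbon bound to an amine nitrogen gives a 1.8-fold lower number from compound 2 to compound 3 (0.24 log units; within the scatter), so this exchange, which also removes the hydrogen-bond donor counted on the leaving group, does not clearly separate the two compounds. Compounds 1 and 2 differ in two places at once, but with the benzyl part held the same, 2-methoxyphenoxy in place of phenyl on an aromatic carbon gives a 2.2-fold higher number from compound 1 to compound 3 (0.33 log units; beyond the scatter), a modest step that lies just beyond the scatter. Nothing available here explains either step.

Open, as far as these compounds go, is whether a longer chain in place of the three-carbon amine chain would shift the number. Also open, from the compounds shown here alone, is what a carboxylic acid on the benzyl ring would do.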